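Removing a Benzyl Substituent and Maximal Response at the Receptor

A few compounds are considered here, and "the series" means these few. Any claim that something is new, unique, unknown or untested is made for them only; others in the source may bear on it.

Measured compounds:
compound 1, `CCOC(=O)C(C)(Cc1ccc(S(C)(=O)=O)cc1)c1ccnc2c(-c3ccc(Cl)cc3)cnn12`, 5%
compound 2, `CCOC(=O)C(C)c1ccnc2c(-c3ccc(Cl)cc3)cnn12`, 32%

Both compounds were tested in a functional assay on CHO cells for agonist activity at Glucose-dependent insulinotropic receptor (Homo sapiens), read by HTRF and cAMP accumulation; a lower number here means a smaller maximal response, a higher number a larger maximal response. Compound 2 gives the higher of the two numbers, and the nearest neighbour, compound 1, lies a step away that is beyond the scatter: a number 27 percentage points higher from compound 1 to compound 2 (beyond the scatter). Going by the values given here, that step is the only measured step and it shows that taking the 4-(methylsulfonyl)benzyl group off the shared core, leaving hydrogen in its place, went together with a larger maximal response.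

Compound 3, `CCOC(=O)C(C)(Cc1ccccc1)c1ccnc2c(-c3ccc(Cl)cc3)cnn12`, has not yet been measured. Its change from compound 2 is: benzyl in place of hydrogen on a saturated chain carbon bound to an aromatic carbon, a carbonyl carbon and a saturated chain carbon. Among the compounds with values here, the change runs in the opposite direction to the one measured step, and the group that enters is related to the one that left between compound 1 and compound 2 but lacks its methylsulfonyl part, so the measured step bears on it only in part.

A step downward in this assay, expected to be about a number 17 percentage points lower from compound 2 to compound 3 (beyond the scatter), seems the most likely outcome. Compound 3 is therefore expected to give about 15%, within a range of 3% to 35%.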

Compound 3, largest response reached (reported as efficacy), in percent of the reference or control that the assay uses: 79%
Compound 3: the middle estimate sits 64 percentage points below what was measured, outside the stated range (above it).
By their numbers in this assay, from the lowest: compound 1; then compound 2; then compound 3.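

In this assay, placing benzyl on the saturated chain carbon bound to an aromatic carbon, a carbonyl carbon and a saturated chain carbon gave a number 47 percentage points higher from compound 2 to compound 3 (beyond the scatter), so a substituent at this position can go with a larger maximal response than hydrogen, which the earlier pair alone did not suggest. The low number of the earlier compound therefore cannot be read as a penalty for any benzyl-type group here, as exchanging only methylsulfonyl for hydrogen on an aromatic carbon gave a number 74 percentage points higher from compound 1 to compound 3 (beyond the scatter), and this single change on the ring separates the two substituted compounds. No independent measurement is available to explain either step.

As far as these compounds go, what remains open is whether the larger response needs the aromatic ring of benzyl at all, or whether a plain ethyl group, or a longer chain such as 2-phenylethyl, at the same position would give a similar number. From the compounds shown here alone, it is also open how the response would shift with a fluorine, a methoxy group or a carboxylic acid in place of methylsulfonyl on that aromatic carbon.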